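Capping a Phenol with a Sulfonyl Group: Expected Cytotoxicity

The compounds below may be only part of what the source reports. "The series", "measured", "known", "first", "only" and "open" are said of these compounds alone.

Of the compounds shown here, three have been measured and a fourth waits. Compound 1 `Cc1c(O)ccc2c1[C@H](Cn1cc(-c3ccccc3)nn1)[C@@]13CC(=O)[C@@](C)(CC[C@@H]21)C3` carries a free hydroxy group on an aromatic ring. In a functional assay on A549 cells (Homo sapiens) for cytotoxicity, read by MTT assay, with a stated time of 4 days (on this read-out higher numbers stand for weaker inhibition and lower numbers for stronger inhibition), compound 1 gives only a limit, > 20000 nM. Compound 2 `Cc1ccc(S(=O)(=O)Oc2ccc3c(c2C)[C@H](Cn2cc(-c4ccccc4)nn2)[C@@]24CC(=O)[C@@](C)(CC[C@@H]32)C4)cc1` differs from it in one place, ((4-methylphenyl)sulfonyl in place of hydrogen on an oxygen on an aromatic ring). In this assay compound 2 also gives only a limit, > 20000 nM. The step that the two limits leave unreadable from compound 1 to compound 2 cannot be read because the limit of > 20000 nM in this assay, at which 2 of the 3 values shown sit, covers both of its ends, so the direction of this change is not known from the measured pair.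

Compound 3 `C=C1C(=O)[C@]23C[C@@]1(O)CC[C@H]2c1ccc(O)c(C)c1[C@@H]3Cn1cc(-c2ccc(F)cc2)nn1` has a different core; the difference between its core and the core of compound 1 is not broken down here. In this assay, going by the values given here, compound 3 gives 940 nM, the only real number among the measured compounds. Compound 4 `C=C1C(=O)[C@]23C[C@@]1(O)CC[C@H]2c1ccc(OS(=O)(=O)c2ccc(C)cc2)c(C)c1[C@@H]3Cn1cc(-c2ccc(F)cc2)nn1` is its unmeasured partner, made by the same change as before, ((4-methylphenyl)sulfonyl in place of hydrogen on an oxygen on an aromatic ring), at a place described in the same words for both pairs.

Among the compounds with values here, since the one earlier example of this change is unreadable, the expectation for compound 4 rests on compound 3 alone. Compound 4 is estimated at 2500 nM in this assay, somewhere between 500 nM and 20000 nM. The step this estimate implies, a 2.7-fold higher number from compound 3 to compound 4 (0.42 log units; beyond the scatter), is expected to be modest, with a real chance that only a limit is reported.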

Compound 4, half-maximal inhibitory concentration: 1950 nM
For compound 4 the middle estimate is 1.3-fold (0.11 log units) above the measured one; the range from low to high includes it.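

In this assay, placing (4-methylphenyl)sulfonyl in place of hydrogen on the oxygen on an aromatic ring gives a 2.1-fold higher number from compound 3 to compound 4 (0.32 log units; beyond the scatter), so on the core shared by these two compounds the hydroxy group can be capped and a real number remains, although that number stands for modestly weaker inhibition. On the core of compound 1 the same change cannot be read, because both ends of the pair are limits of the assay and not numbers: the limit of > 20000 nM in this assay, at which 2 of the 4 values shown sit. The series therefore offers a single readable example of this change, and that example does not show whether the step would keep its size, or even its direction, on the other core, so nothing here establishes that the change carries from one core to the other.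

Among the compounds shown, only hydrogen and (4-methylphenyl)sulfonyl sit on this oxygen, which leaves open what a small methyl group, an acetyl group or a longer chain ending in an amine would do there. As far as these compounds go, it also remains open whether the sulfonyl group's own ring matters, for instance if a carboxylic acid replaced its methyl group.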